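Swapping the benzyl aryl group on the hydroxyisobutyl pyrazole series

The source may hold more compounds than are shown below. What is called first, only, known or untested is meant among the compounds shown, and "the series" means these compounds.

Of the compounds shown here, two have been tested so far. Compound 1 `CC(Oc1ccnc(Nc2cnn(C3CCN(C)CC3)c2)c1)c1cccc(C(=O)NCc2ccc(Cl)c(C(F)(F)F)c2)c1` gives in a functional assay on NCI-H3122 cells (Homo sapiens) for antiproliferative activity, read by MTT assay, with a stated time of 48 h (on this read-out higher numbers stand for weaker inhibition and lower numbers for stronger inhibition), a value of 8000 nM. Compound 2 `Cc1ccc(CNC(=O)c2cccc(C(C)Oc3ccnc(Nc4cnn(CC(C)(C)O)c4)c3)c2)cc1` is reported in this assay only as a limit, > 100000 nM. Compound 2 thus stands at the limit of > 100000 nM in this assay, at which 1 of the 2 values shown sits, and its gap to compound 1 cannot be counted as a step of known size. Compound 3 `CC(Oc1ccnc(Nc2cnn(CC(C)(C)O)c2)c1)c1cccc(C(=O)NCc2ccc(Cl)c(C(F)(F)F)c2)c1` has not yet been measured in this assay. It differs from compound 2 in one place: 4-chloro-3-(trifluoromethyl)phenyl in place of 4-methylphenyl on a saturated chain carbon bound to an amide-type nitrogen. Compound 3 then carries the same benzylic amide group as compound 1, with the pyrazole substituent of compound 2. Since compound 1 reaches 8000 nM, the step of an at least 6.6-fold lower number from compound 2 to compound 3 (0.82 log units; beyond the scatter) is expected to bring compound 3 to a measurable value. Compound 3 is therefore estimated to give 15000 nM, within a range of 4000 nM to 70000 nM.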

Compound 3, half-maximal inhibitory concentration: 38400 nM
Compound 3: the middle estimate sits 2.6-fold (0.41 log units) below what was measured, and the stated range covers the measured number.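

In this assay, placing 4-chloro-3-(trifluoromethyl)phenyl in place of 4-methylphenyl on the saturated chain carbon bound to the amide-type nitrogen gives an at least 2.6-fold lower number from compound 2 to compound 3 (0.41 log units; beyond the scatter), so this change brings the hydroxyisobutyl pyrazole series to a readable number. The size of that step has only a bound, as the value for compound 2 is a limit and not a number: the limit of > 100000 nM in this assay, at which 1 of the 3 values shown sits. With the benzylic amide group now held constant, the substituent on the aromatic nitrogen can also be compared, and 2-hydroxy-2-methylpropyl in place of 1-methylpiperidin-4-yl gives a 4.8-fold higher number from compound 1 to compound 3 (0.68 log units; beyond the scatter).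

From the compounds shown here alone, whether the chlorine or the trifluoromethyl alone would carry the step on the benzyl group stays open. Going by these compounds, it is also open how a chain ending in a primary amine or a carboxylic acid would read on the aromatic nitrogen.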